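Methoxy additions on the aryl sulfonate of two cores

The source may hold more compounds than are shown below. What is called first, only, known or untested is meant among the compounds shown, and "the series" means these compounds.

Compound 1 `CCN1CCN(c2ccc(S(=O)(=O)Oc3ccc(OC)c(OC)c3)cc2)C1=O`, compound 2 `CCN1CCN(c2ccc(S(=O)(=O)Oc3ccc(OC)cc3)cc2)C1=O`, compound 3 `CCCN1CCN(c2ccc(S(=O)(=O)Oc3cccc(OC)c3)cc2)C1=O` and the unmeasured compound 4 `CCCN1CCN(c2ccc(S(=O)(=O)Oc3cc(OC)cc(OC)c3)cc2)C1=O` are compared in a functional assay on HT-29 cells (Homo sapiens) for antiproliferative activity, read by sulforhodamine B assay, with a stated time of 48 h; on this read-out higher numbers stand for weaker inhibition and lower numbers for stronger inhibition. Compound 1 gives 37000 nM in this assay. Compound 2 gives 60000 nM in this assay. Compound 3 gives 25000 nM in this assay, the lowest of the three numbers; its distance to compound 1 is within the scatter, its distance to compound 2 is beyond it. The difference between the core of compound 2 and the core of compound 3 is not broken down here.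

The measured step of a 1.6-fold lower number from compound 2 to compound 1 (0.21 log units; within the scatter) comes from the change (methoxy in place of hydrogen on an aromatic carbon), placed ortho to a methoxy group and meta to a large group. The change from compound 3 to compound 4 is methoxy in place of hydrogen on an aromatic carbon, placed meta to a methoxy group and meta to a large group. Since the surroundings of the place differ in the relation to the methoxy group, this is the same kind of change rather than the same change.

For compound 4 a step of about a 1.4-fold lower number from compound 3 to compound 4 (0.14 log units; within the scatter) is expected, roughly matching the earlier one, which rests on compound 2 and compound 1 having shown a 1.6-fold lower number from compound 2 to compound 1 (0.21 log units; within the scatter) and on the two cores being otherwise closely related. Compound 4 is therefore estimated at 18000 nM in this assay, with a range from 8000 nM to 40000 nM.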

Compound 4, half-maximal inhibitory concentration: 16000 nM
For compound 4 the middle estimate is 1.1-fold (0.05 log units) above the measured one, within the range that was stated.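

In this assay, methoxy in place of hydrogen on an aromatic carbon gives a 1.6-fold lower number from compound 3 to compound 4 (0.19 log units; within the scatter), and as far as two pairs can show, the change carries from one core to the other with a step of matching size: the same change on two cores in this assay, a 1.6-fold lower number (0.21 log units; within the scatter) from compound 2 to compound 1 and a 1.6-fold lower number (0.19 log units; within the scatter) from compound 3 to compound 4, 1.0-fold (0.02 log units) apart, within the scatter of two such steps

This agreement is only between two small steps, each within the scatter, so neither pair on its own shows that the added methoxy shifts the number on its core, and the match cannot be read as a firm additive contribution. The place in compound 4 is meta to a methoxy group and meta to a large group, whereas the earlier step has a different relation to the methoxy group, so the notes record the same kind of change at two different places, and two pairs give no rule for other cores of the series.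

As far as these compounds go, whether a group other than methoxy, such as ethoxy, hydroxyl or an amine, would also give matching steps on the two cores remains open. Also open, from the compounds shown here alone, is how the step behaves on a core with a longer chain than propyl, and how the core difference itself contributes to the numbers.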